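Longer Side Chains and Stronger Growth Inhibition

This account rests on a few compounds, and the source may have more. Where it says the series, first, only, none or still open, it means among the compounds named here.

Measured in a functional assay on HCT-116 cells (Homo sapiens) for antiproliferative activity, read by MTT assay, with a stated time of 48 h; on this read-out higher numbers stand for weaker inhibition and lower numbers for stronger inhibition:
compound 1, `CCCC(CCO)n1cnc2c(Cl)ncnc21`, gives > 50000 nM, a limit of this assay and not a number.
compound 2, `CCCCC(CCO)n1cnc2c(Cl)ncnc21`, gives > 50000 nM, likewise a limit.
compound 3, `CCCCCCCCCC(CCO)n1cnc2c(Cl)ncnc21`, gives 890 nM.

Two of the three results sit at the limit of > 50000 nM in this assay, at which 2 of the 3 values shown sit, so only compound 3 yields a number. The change methyl in place of hydrogen on a saturated chain carbon, four bonds along the chain from an aromatic nitrogen produced a step that the two limits leave unreadable from compound 1 to compound 2. Compound 4, `CCCCCCCCCCC(CCO)n1cnc2c(Cl)ncnc21`, carries the same kind of change, (methyl in place of hydrogen on a saturated chain carbon, ten or more bonds along the chain from an aromatic nitrogen), though its place along the chain differs from that of the change between compound 1 and compound 2. The cores of compound 1 and compound 3 differ by hexyl in place of hydrogen on a saturated chain carbon, four bonds along the chain from an aromatic nitrogen, a change that gave an at least 56-fold lower number from compound 1 to compound 3 (1.74 log units; beyond the scatter). Because an at least 56-fold lower number from compound 2 to compound 3 (1.74 log units; beyond the scatter) also points toward lower numbers with longer chains, compound 4 is expected to show a 1.6-fold lower number from compound 3 to compound 4 (0.21 log units; within the scatter) in this assay. Compound 4 is estimated at 550 nM, between 150 nM and 2000 nM.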

Compound 4, half-maximal inhibitory concentration: 4930 nM
Beside the measured number, compound 4's estimate is 9.0-fold (0.95 log units) below it; the whole stated range lies below it.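

In this assay, methyl in place of hydrogen on a saturated chain carbon, ten or more bonds along the chain from an aromatic nitrogen, gave a 5.5-fold higher number from compound 3 to compound 4 (0.74 log units; beyond the scatter), so the trend toward lower numbers with longer chains does not hold at compound 4. Heptyl in place of hydrogen gave an at least 10-fold lower number from compound 1 to compound 4 (1.00 log units; beyond the scatter), and hexyl in place of hydrogen gave an at least 10-fold lower number from compound 2 to compound 4 (1.00 log units; beyond the scatter). Hexyl thus lowers the number on both cores, which shows that the direction carries over but not that the size does: the same change on two cores in this assay, an at least 56-fold lower number (1.74 log units; beyond the scatter) from compound 1 to compound 3 and an at least 10-fold lower number (1.00 log units; beyond the scatter) from compound 2 to compound 4; the limit leaves it open whether they differ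

Going by these compounds, those values are limits and not numbers, so the true sizes of these steps stay unknown: the limit of > 50000 nM in this assay, at which 2 of the 4 values shown sit. Whether a longer chain would raise the number further, and which chain length gives the lowest number, stays open.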